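A few compounds are considered here, and "the series" means these few. Any claim that something is new, unique, unknown or untested is made for them only; others in the source may bear on it.

Compound 1 `COCOc1cc(/C=C/C(=O)OCC(=O)Nc2ccc(Cl)cc2)ccc1OCc1ccccc1`: > 200000 nM
Compound 2 `COCOc1cc(/C=C/C(=O)OCC(=O)NN2CCOCC2)ccc1OCc1ccccc1`: > 200000 nM
Compound 3 `O=C(COC(=O)/C=C/c1ccc(O)c(O)c1)NN1CCOCC1`: > 200000 nM

These values come from a functional assay on HeLa cells (Homo sapiens) for cytotoxicity, read by MTT assay, with a stated time of 72 h; on this read-out lower numbers stand for stronger inhibition and higher numbers for weaker inhibition. For compound 1, compound 2 and compound 3 alike the reported value is a limit of this assay and not a number: none of the three reduced the growth of the cells far enough for a concentration to be read. The step that the two limits leave unreadable from compound 2 to compound 1 is therefore not readable, although the structural change itself is clear: 4-chlorophenyl in place of morpholin-4-yl on an amide-type nitrogen. Compound 4 `O=C(COC(=O)/C=C/c1ccc(O)c(O)c1)Nc1ccc(Cl)cc1` has not yet been measured in this assay. It relates to compound 3 by the same change at the same place, (4-chlorophenyl in place of morpholin-4-yl on an amide-type nitrogen). The cores of compound 2 and compound 3 differ, but that difference is not broken down here. Within the data shown here, the expectation for compound 4 rests on (the limit of > 200000 nM in this assay, at which 3 of the 3 values shown sit), where every value so far sits. The step that the limit leaves unreadable from compound 3 to compound 4 is estimated to be small, matching the unreadable step between compound 2 and compound 1. Compound 4 is expected to give 300000 nM in this assay, most likely as another limit rather than a number.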

Compound 4, half-maximal inhibitory concentration: 195000 nM
For compound 4 the middle estimate is 1.5-fold (0.19 log units) above the measured one; the measured number falls inside the stated range.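

In this assay, putting 4-chlorophenyl in place of morpholin-4-yl on the amide-type nitrogen gives an at least 1.0-fold lower number from compound 3 to compound 4 (0.01 log units; that floor lies within the scatter). Going by these compounds, this step is only a floor, with a measured number at one end and a limit at the other, so on the core of compound 3 it shows that the change did not leave the assay's range far behind, but the true size of the step stays unknown and could be larger. It does not show that the change carries from one core to another, since the same change on the core of compound 2 cannot be read and the two steps cannot be compared, because nearly all the values sit at one limit: the limit of > 200000 nM in this assay, at which 3 of the 4 values shown sit.

The compounds shown leave open what other groups on this nitrogen would do, such as an unsubstituted phenyl ring or a short chain ending in an amine or a carboxylic acid. They also leave open whether any such group would bring a number clearly readable on both cores.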